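Swapping the aroyl group on compound 3 for an aminoacetyl

The source may hold more compounds than are shown below. What is called first, only, known or untested is meant among the compounds shown, and "the series" means these compounds.

Measured compounds in a functional assay on MGC-803 cells (Homo sapiens) for cytotoxicity, read by MTT assay, with a stated time of 48 h; on this read-out lower numbers stand for stronger inhibition and higher numbers for weaker inhibition:
Compound 1 `CCC(=O)N1N=C(C)CC1c1cc(Br)ccc1O` gives 50300 nM.
Compound 2 `CC(=O)Oc1ccccc1C1CC(C)=NN1C(=O)CCl` gives 3010 nM.
Compound 3 `O=C(c1ccccc1Cl)N1N=C(c2cc3ccccc3oc2=O)CC1c1ccccc1` gives 6640 nM.

Compound 3 stands second highest of the three numbers: compound 2 lies below it, and compound 1 lies above it, and both gaps are beyond the usual scatter. No two of the measured compounds differ in just one place, so no single step can be read off among them; the three only share a core and differ at several points at once.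

Compound 4 `O=C(CN1CCC(O)CC1)N1N=C(c2cc3ccccc3oc2=O)CC1c1ccccc1` is the unmeasured partner of compound 3. The change is (4-hydroxypiperidin-1-yl)methyl in place of 2-chlorophenyl on a carbonyl carbon, so an aromatic group on the carbonyl carbon gives way to a saturated ring bearing a hydroxyl group, while the rest of compound 3 is kept.

Going by the values given here, with no comparable step among the measured compounds, the size of this change in this assay is uncertain; the author expects a step from compound 3 to compound 4 of a 1.2-fold higher number from compound 3 to compound 4 (0.08 log units; within the scatter), that is, little change beyond the scatter in either direction. Compound 4 is therefore estimated at 8000 nM, with a range from 2500 nM to 25000 nM.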

Compound 4, half-maximal inhibitory concentration: "not active" (no number reported)
Nothing numeric was reported for compound 4; no gap can be computed for the estimate.
By their numbers in this assay, from the lowest: compound 2; then compound 3; then compound 1.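

In this assay, going by these compounds alone, compound 4 is reported only as not active, without a number, so no step from compound 3 to compound 4 can be read. The compounds shown leave open how large the difference between them is. Nothing shown here explains the result.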